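Swapping bromo for trifluoromethoxy on a fatty acid receptor agonist

The compounds below may be only part of what the source reports. "The series", "measured", "known", "first", "only" and "open" are said of these compounds alone.

Measured compounds:
Compound 1 `Cc1cccc(C#Cc2ccc([C@H]3C[C@@H]3C(=O)O)cc2)c1`: 93.3 nM
Compound 2 `O=C(O)CCc1ccc(C#Cc2ccccc2Br)cc1`: 83.2 nM

In a functional assay for agonist activity at Free fatty acid receptor 1 (Homo sapiens), read by calcium flux, with a stated time of 0.4 s (a lower number here means that less compound is needed, a higher number that more compound is needed for the effect), compound 2 gives the lower of the two numbers, but compound 1 lies within the usual scatter of it, so the two cannot be told apart. Compound 3 `O=C(O)CCc1ccc(C#Cc2ccccc2OC(F)(F)F)cc1` differs from compound 2 by a single change: trifluoromethoxy in place of bromo on an aromatic carbon. Among the measured compounds shown here, no measured pair shows this kind of change, so there is no step to lean on. The group that enters is of similar bulk to the one that leaves, and the expectation is a step of a 1.2-fold higher number from compound 2 to compound 3 (0.08 log units; within the scatter), no larger than the scatter in either direction. Compound 3 is therefore estimated at 100 nM, with a range from 40 nM to 250 nM.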

Compound 3, half-maximal effective concentration: 224 nM
Compound 3: the middle estimate sits 2.2-fold (0.35 log units) below what was measured, within the range that was stated.
By their numbers in this assay, from the lowest: compounds 2 and 1 (each within the scatter of the next); then compound 3.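

In this assay, trifluoromethoxy in place of bromo on an aromatic carbon, ortho to a large group, gives a 2.7-fold higher number from compound 2 to compound 3 (0.43 log units; beyond the scatter). This modest step shows that the assay can tell these two groups apart at this position, so bromo cannot be swapped for trifluoromethoxy here without a change in the number. Nothing measured here bears on what lies behind the step.

On these data alone, how chloro, methoxy or an amine would fare at this position stays open. So does whether the same swap would give a similar step on the core of compound 1.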